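A few compounds are considered here, and "the series" means these few. Any claim that something is new, unique, unknown or untested is made for them only; others in the source may bear on it.

In a functional assay on Malme-3M cells (Homo sapiens) for inhibition, read by sulforhodamine B assay, with a stated time of 48 h, tested at 10 uM (a higher number here means more inhibition of growth at the concentration tested, a lower number less inhibition of growth), three compounds have been measured. Compound 1 `O=C(O)c1ccc(Nc2ccnc(SCC(=O)c3ccc(C(F)(F)F)cc3)n2)cc1` gives 30%, compound 2 `CCOC(=O)c1ccc(Nc2ccnc(SCC(=O)c3ccc(C#N)cc3)n2)cc1` gives 19%, and compound 3 `CC(=O)c1cccc(Nc2ccnc(SCC(=O)c3ccc(-c4ccccc4)cc3)n2)c1` gives 17%. Compound 3 thus has the lowest of the three numbers; compound 2 lies within the scatter of it, while compound 1 lies beyond the scatter above it. Compound 4 `CC(=O)c1ccc(Nc2ccnc(SCC(=O)c3ccc(-c4ccccc4)cc3)n2)cc1` has not yet been measured. It differs from compound 3 in one place: 4-acetylphenyl in place of 3-acetylphenyl on a nitrogen on an aromatic ring. The two share every atom and differ only in where the acetyl sits on the ring attached to that nitrogen. Within the data shown here, no measured pair in this set isolates such a change, so no step beyond the scatter in this assay is expected in either direction. Compound 4 is therefore estimated at 20%, between 5% and 38%, which means an expected step of a number 3 percentage points higher from compound 3 to compound 4 (within the scatter).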

Compound 4, percent growth inhibition at one concentration: 14%
Estimate against measurement, compound 4: 6 percentage points above, within the range that was stated.
By their numbers in this assay, from the lowest: compounds 4, 3 and 2 (each within the scatter of the next); then compound 1.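

In this assay, among these compounds, the move of the acetyl gives the first comparison in this set that differs in one place: 4-acetylphenyl in place of 3-acetylphenyl on the nitrogen gives a number 3 percentage points lower from compound 3 to compound 4 (within the scatter). The two placements of the acetyl therefore cannot be told apart in this assay. Nothing at hand bears on this result.

The compounds shown leave open whether an amine or a sulfonamide in place of the acetyl on this ring, with the rest of compound 4 unchanged, would read any differently.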